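This account rests on a few compounds, and the source may have more. Where it says the series, first, only, none or still open, it means among the compounds named here.

Among the measured compounds shown here, in a functional assay on HepG2 cells (Homo sapiens) for cytotoxicity, read by MTT assay, with a stated time of 24 h (on this read-out lower numbers stand for stronger inhibition and higher numbers for weaker inhibition), two compounds have numbers so far. Compound 1 (`COc1cc(/C=C2\CN(C)C/C(=C\c3ccc(Cl)c(Cl)c3)C2=O)cc(OC)c1`) gives 3840 nM, and compound 2 (`CN1C/C(=C\c2ccc(F)cc2)C(=O)/C(=C/c2ccc(C#N)cc2)C1`) gives 6140 nM. Compound 2 stands level with compound 1: the two values lie within the usual scatter of each other, so neither can be ranked above the other.

Still unmeasured is compound 3 (`CN1C/C(=C\c2ccc(Br)cc2)C(=O)/C(=C/c2ccc(C#N)cc2)C1`). It departs from compound 2 in one place: bromo in place of fluoro on an aromatic carbon. This is bromo in place of fluoro on an aromatic carbon, para to a large group, so that 4-fluorophenyl becomes 4-bromophenyl. The rest of the structure stays the same.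

For the measured compounds named here, no measured pair here differs in one place, so the data do not show how this assay responds to a single exchange, and they support no direction. The expectation therefore stays anchored on compound 2 at 6140 nM. The estimated 1.2-fold lower number from compound 2 to compound 3 (0.09 log units; within the scatter) is expected to stay within the scatter. For compound 3 the expected value is 5000 nM, with an estimated range from 2200 nM to 11000 nM.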

Compound 3, half-maximal inhibitory concentration: 4840 nM
For compound 3 the middle estimate is 1.0-fold (0.01 log units) above the measured one, and the stated range covers the measured number.
By their numbers in this assay, from the lowest: compounds 1, 3 and 2 (each within the scatter of the next).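

In this assay the exchange of fluoro for bromo gives the series its first reading of a single change, and the step is a 1.3-fold lower number from compound 2 to compound 3 (0.10 log units; within the scatter). On an aromatic carbon para to a large group, 4-fluorophenyl and 4-bromophenyl therefore stand level, and this one exchange does not separate compound 2 from compound 3 on this read-out. Compound 1 and compound 2 differ in more than one place and could say nothing about this position alone, whereas this pair isolates it, and no measurement in hand speaks to why the two compounds stand level.

The compounds shown leave open whether this position stays as flat for a group that is not a halogen, such as an amine, a hydroxyl or a carboxylic acid, since fluoro and bromo are the only two groups compared here. They also leave open whether a change at the nitrile of compound 2 and compound 3, for instance to an amide, would move the number beyond the usual scatter.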